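Chloro to methyl in a growth-inhibiting pair

This account rests on a few compounds, and the source may have more. Where it says the series, first, only, none or still open, it means among the compounds named here.

compound 1 (`Cc1ccnc2nc(-c3cccc(Cl)c3)cc(O)c12`) gives 15.9 nM
compound 2 (`Cc1ccc2c(O)cc(-c3cccc(Cl)c3)nc2n1`) gives 25.7 nM

Both values come from a functional assay on HCT-116 cells (Homo sapiens) for antiproliferative activity (a lower number here means a stronger inhibitor of growth, a higher number a weaker inhibitor of growth), and lie within the usual scatter of each other, so compound 2 cannot be ranked against compound 1. These two numbers are all that is known so far.

The next compound is compound 3 (`Cc1cccc(-c2cc(O)c3ccc(C)nc3n2)c1`). It has methyl in place of chloro on an aromatic carbon, on a six-membered aromatic ring of carbon only, meta to a large group (methyl in place of chloro on an aromatic carbon). Among the measured compounds shown here, no measured pair shows what this swap does, so any forecast is loose. Compound 2 at 25.7 nM is the starting point, and a slight loss of strength is expected, with the estimated change (a 1.4-fold higher number from compound 2 to compound 3 (0.13 log units; within the scatter)) staying within the scatter. For compound 3 the estimated value is 35 nM (expected range 10 nM to 120 nM).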

Compound 3, concentration for 50% growth inhibition: 120 nM
The estimate for compound 3 lay 3.4-fold (0.54 log units) below the measured number; low and high end bracket the measured number.
By their numbers in this assay, from the lowest: compounds 1 and 2 (each within the scatter of the next); then compound 3.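

In this assay, methyl in place of chloro on the six-membered aromatic ring of carbon only, meta to a large group, gives a 4.7-fold higher number from compound 2 to compound 3 (0.67 log units; beyond the scatter), so compound 3 is the weaker inhibitor of growth. This shows that the position is sensitive to which group it carries, even though chloro and methyl match in heavy-atom count and neither adds a hydrogen-bond donor or acceptor. No measurement at hand explains why the two groups differ.

Still open, from the compounds shown here alone, is whether chloro is unusually favourable here or methyl unusually poor, a question that groups such as fluoro, methoxy or an amine at this place could help to settle. It is also unknown whether the same swap would cost as much on the core of compound 1, where the other methyl sits elsewhere.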